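Shortening the ether chain on a shared quinoline-free core

This account rests on a few compounds, and the source may have more. Where it says the series, first, only, none or still open, it means among the compounds named here.

The measured compounds and their values are as follows.
Compound 1, `CCCCCCOc1ccc2c(Cl)ccnc2c1`: 2420 nM
Compound 2, `CCCCCCOc1ccc2c(NCCN(C)C)ccnc2c1`: 1370 nM
Compound 3, `Fc1ccc(COc2ccc3c(Cl)ccnc3c2)cc1`: 3010 nM

In a functional assay on HepG2 cells (Homo sapiens) for cytotoxicity, read by MTT assay, with a stated time of 48 h (a higher number here means a weaker inhibitor, a lower number a stronger inhibitor), compound 1 gives 2420 nM, which is the second highest of the three numbers. Its nearest neighbour is compound 3 with 3010 nM, and the furthest is compound 2 with 1370 nM; all three numbers lie within the scatter of one another, so no order among them can be claimed. Within the data shown here, the only step between compounds that differ in one place is a 1.8-fold lower number from compound 1 to compound 2 (0.25 log units; within the scatter), and it concerns the substituent on the aromatic carbon, not the ether.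

Compound 4, `CC(C)Oc1ccc2c(Cl)ccnc2c1`, has not yet been measured. It differs from compound 1 by isopropyl in place of hexyl on an oxygen on an aromatic ring. Among the measured compounds shown here, no measured step changes this group, so nothing directly bears on it. Compound 1 and compound 3 carry different groups on the same oxygen and show numbers within the scatter of each other, which is the only hint available. The expectation is therefore no step beyond the scatter, that is a 1.2-fold higher number from compound 1 to compound 4 (0.09 log units; within the scatter). Compound 4 is estimated at 3000 nM, with a range from 1200 nM to 8000 nM.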

Compound 4, half-maximal inhibitory concentration: 2050 nM
For compound 4 the middle estimate is 1.5-fold (0.17 log units) above the measured one; measured number inside the range.
By their numbers in this assay, from the lowest: compounds 2, 4, 1 and 3 (each within the scatter of the next, the first and the last beyond it).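

In this assay, among these compounds, the exchange of hexyl for isopropyl on the oxygen on an aromatic ring gives a 1.2-fold lower number from compound 1 to compound 4 (0.07 log units; within the scatter) and this is the first direct reading of a change at this position, since the only earlier step concerned the substituent on the aromatic carbon. With chloro kept on the shared core, the assay does not separate the two alkyl groups, so on this evidence hexyl is not needed in full at this oxygen for a number in this range. No measurement is available that bears on why the two compounds read alike.

The compounds shown leave open whether any group at this oxygen can move the number beyond the scatter, for instance a chain longer than hexyl, or a chain ending in an amine or a carboxylic acid. They also leave open whether isopropyl in place of hexyl would read the same on the core of compound 2, which carries (2-(dimethylamino)ethyl)amino in place of chloro.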